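Shortening the Long Chain of Compound 1

The source may hold more compounds than are shown below. What is called first, only, known or untested is meant among the compounds shown, and "the series" means these compounds.

- compound 1 `CCCCCCCCCCCCCCCCOP(=O)(O)OCCSC(=S)N1CCCCCC1` gives > 100000 nM (a limit)
- compound 2 `CCCCCCCCOP(=O)(O)OCCSC(=S)N1CCCC1` gives 28300 nM
- compound 3 `CCCCCCCCCCCCCCCCOP(=O)(O)OCCSC(=S)N1CCN(C)CC1` gives > 100000 nM (a limit)

All three were tested in an ADME assay on HEK293 cells (Homo sapiens) for inhibition, read by MTT assay, with stated times of 18 h and 4 h; on this read-out lower numbers stand for stronger inhibition and higher numbers for weaker inhibition. Compound 1 has no exact number, only a limit, and so stands at the limit of > 100000 nM in this assay, at which 2 of the 3 values shown sit.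

Compound 4 `CCCCCCOP(=O)(O)OCCSC(=S)N1CCCCCC1` keeps the rest of compound 1 but has a much shorter chain: hydrogen in place of decyl on a saturated chain carbon, six bonds along the chain from an oxygen on an unsaturated carbon.

Within the data shown here, the only measured step, a step that the two limits leave unreadable from compound 1 to compound 3, concerns another part of the molecule, so no measured step gives the size of this change. The nearest clue is that, with a shorter chain than compound 1 as well but a different group on the thiocarbonyl carbon, compound 2 gives 28300 nM. That single comparison is weak, but it points towards a readable number and stronger inhibition, so a step towards lower numbers is expected. The expected change is an at least 2.5-fold lower number from compound 1 to compound 4 (0.39 log units; beyond the scatter). For compound 4 the estimated value is 40000 nM, with an expected range from 12000 nM to 100000 nM.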

Compound 4, half-maximal inhibitory concentration: 70500 nM
Beside the measured number, compound 4's estimate is 1.8-fold (0.25 log units) below it; low and high end bracket the measured number.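

In this assay, hydrogen in place of decyl gives an at least 1.4-fold lower number from compound 1 to compound 4 (0.15 log units; that floor lies within the scatter). Among these compounds, this is the first change to the long chain of compound 1 that yields a readable number while the azepan-1-yl group stays in place, so compound 4, at 70500 nM, gives this series with that group an exact reference point. Even so, the step is only a floor and not a measured size, and it cannot yet be called a real gain in inhibition, because compound 1 has only a limit: the limit of > 100000 nM in this assay, at which 2 of the 4 values shown sit.

What the compounds shown leave open is how the number changes with chain length between these two compounds, or with a still shorter chain. Also open, on these data alone, is what an amine or a carboxylic acid in place of the decyl would do.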